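The source may hold more compounds than are shown below. What is called first, only, known or untested is meant among the compounds shown, and "the series" means these compounds.

In a functional assay on SGC-7901 cells (Homo sapiens) for antiproliferative activity, read by MTT assay, with a stated time of 72 h (a higher number here means a weaker inhibitor, a lower number a stronger inhibitor), compound 1 `CCOC(=O)c1cc(-c2cc(OC)c(OC)c(OC)c2)c(-c2cccc(Br)c2)s1` gives > 100000 nM, which is a limit of the assay and not a number. Compound 2 `CCOC(=O)c1cc(-c2ccc(OC)c(OCc3ccccc3)c2)c(-c2cc(OC)c(OC)c(OC)c2)s1` gives > 100000 nM, likewise a limit. Going by the values given here, compound 3 `CCOC(=O)c1cc(-c2ccc(OC)c(O)c2)c(-c2cc(OC)c(OC)c(OC)c2)s1` gives 20000 nM, the only true number. Compound 4 `COc1ccc(-c2cc(C(=O)O)sc2-c2cc(OC)c(OC)c(OC)c2)cc1O` differs from it by hydrogen in place of ethyl on an oxygen next to a carbonyl group. Among the compounds with values here, the one measured step, an at least 5.0-fold lower number from compound 2 to compound 3 (0.69 log units; beyond the scatter), lies at another place, so it bears only indirectly. With compound 3 at 20000 nM, a modest move to a higher number in this assay is expected. The expected change is a 2.0-fold higher number from compound 3 to compound 4 (0.30 log units; within the scatter). Compound 4 is estimated at 40000 nM, with an expected range of 10000 nM to 100000 nM.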

Compound 4, half-maximal inhibitory concentration: 17500 nM
For compound 4 the middle estimate is 2.3-fold (0.36 log units) above the measured one, within the range that was stated.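

Hydrogen in place of ethyl on an oxygen next to a carbonyl group gives a 1.1-fold lower number from compound 3 to compound 4 (0.06 log units; within the scatter) in this assay, so the ethoxycarbonyl and carboxy forms read alike in this pair. The earlier step lay at another place, and this one shows that the ethyl can go without a change beyond the scatter. Compound 4 keeps a true number, whereas compounds 1 and 2 stand at a limit of the assay: the limit of > 100000 nM in this assay, at which 2 of the 4 values shown sit.

From the compounds shown here alone, whether an amide or a longer chain on this oxygen would read the same remains open.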